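Nine-membered ring series: changing the aryl group on nitrogen

The compounds below may be only part of what the source reports. "The series", "measured", "known", "first", "only" and "open" are said of these compounds alone.

Measured in a functional assay on A549 cells (Homo sapiens) for antiproliferative activity, read by MTT assay, with a stated time of 72 h; a lower number here means a stronger inhibitor, a higher number a weaker inhibitor:
- compound 1 `C#Cc1cccc(Nc2ncnc3cc(OC)c(OCCCN4CCNCCNCCNCC4)cc23)c1` gives 28600 nM
- compound 2 `COc1cccc(Nc2ncnc3cc(OC)c(OCCCN4CCNCCNCCNCC4)cc23)c1` gives > 50000 nM as a limit
- compound 3 `C#Cc1cccc(Nc2ncnc3cc(OC)c(OCCCN4CCNCCNCC4)cc23)c1` gives > 50000 nM as a limit

Compound 3 has no number of its own and stands only at the limit of > 50000 nM in this assay, at which 2 of the 3 values shown sit, in the data so far. The unmeasured compound 4 `COc1cc2ncnc(Nc3ccc(Br)cc3F)c2cc1OCCCN1CCNCCNCC1` keeps the nine-membered non-aromatic ring of compound 3 and changes the group on the nitrogen: 4-bromo-2-fluorophenyl in place of 3-ethynylphenyl on a nitrogen on an aromatic ring. Cut one bond further out, this reads (3-ethynylphenyl)amino to (4-bromo-2-fluorophenyl)amino.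

Going by the values given here, two measured steps bear on this change. The first alters the same aryl group, with methoxy in place of ethynyl on an aromatic carbon: an at least 1.7-fold higher number from compound 1 to compound 2 (0.24 log units; that floor lies within the scatter). The second alters the ring and gives the starting point: an at least 1.7-fold higher number from compound 1 to compound 3 (0.24 log units; that floor lies within the scatter). Both steps end at a limit, so each gives only a floor. Among the compounds with values here, no measured compound carries the 4-bromo-2-fluorophenyl group.

No step beyond the scatter is therefore expected in this assay in either direction, and another limit is the likeliest report. The expected size of the change is an at least 1.2-fold lower number from compound 3 to compound 4 (0.09 log units; that floor lies within the scatter). For compound 4 the estimated value is 40000 nM, with an expected range from 15000 nM to 100000 nM.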

Compound 4, half-maximal inhibitory concentration: 16100 nM
Compound 4: the middle estimate sits 2.5-fold (0.40 log units) above what was measured; low and high end bracket the measured number.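

In this assay, going by these compounds alone, the group on the nitrogen is the first place in the nine-membered ring series to give a step beyond the scatter: an at least 3.1-fold lower number from compound 3 to compound 4 (0.49 log units; beyond the scatter). The earlier steps shown here, including the change from ethynyl to methoxy on the aryl group, gave only floors within the scatter, so they showed no readable effect of any change; 4-bromo-2-fluorophenyl in place of 3-ethynylphenyl now brings a compound with the nine-membered ring to a measured number rather than a limit. The size of this step remains a floor, as its starting point is a limit and not a number: the limit of > 50000 nM in this assay, at which 2 of the 4 values shown sit.

Still open, going by these compounds, is whether the bromine or the fluorine alone would carry this step, and whether a chlorine or a nitrile on the same aryl ring would do the same. Also open, on these data alone, is whether 4-bromo-2-fluorophenyl moves the number in the same direction on the larger ring of compound 1, which would show if the step depends on the ring at the end of the chain.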